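This account rests on a few compounds, and the source may have more. Where it says the series, first, only, none or still open, it means among the compounds named here.

Working notes on the series. Among the compounds with values here, compound 3 `CC(=O)NCCCc1cccc2oc(CCCCc3ccccc3)cc12` gives 127 nM in an assay on NIH3T3 cells for binding affinity to melatonin receptor type 1B (Homo sapiens) (a higher number here means a weaker inhibitor, a lower number a stronger inhibitor), the highest of the three numbers so far. Compound 2 `CCNC(=O)NC[C@@H]1C[C@H]1c1cccc2oc(CCCCc3ccccc3)cc12` gives 90 nM, which lies within the scatter of compound 3. Compound 1 `CCC(=O)NC[C@@H]1CC1c1cccc2oc(CCCCc3ccccc3)cc12` gives 2.8 nM; the step of a 45-fold higher number from compound 1 to compound 3 (1.66 log units; beyond the scatter) is the only one on record that reaches compound 3, and it exchanges the whole amide-bearing arm at once, so it does not separate the acyl part from the rest.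

Compound 4 `CCCC(=O)NCCCc1cccc2oc(CCCCc3ccccc3)cc12` differs from compound 3 by ethyl in place of hydrogen on a saturated chain carbon bound to a carbonyl carbon. Within the data shown here, no measured pair isolates this change: compound 1 carries a propanoyl amide but also a cyclopropane, and compound 2 carries a urea. Among the measured compounds shown here, no step therefore bears directly on it, and the expectation rests only on the fact that the arm of compound 3 is the one giving the highest number so far. A modest step toward a lower number is expected, a 2.5-fold lower number from compound 3 to compound 4 (0.40 log units; beyond the scatter), though a result within the scatter remains possible. Compound 4 is estimated at 50 nM, with a range from 15 nM to 200 nM.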

Compound 4, inhibition constant: 82 nM
Estimate against measurement, compound 4: 1.6-fold (0.21 log units) below, within the range that was stated.
By their numbers in this assay, from the lowest: compound 1; then compounds 4, 2 and 3 (each within the scatter of the next).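

In this assay, the propyl arm does not distinguish acetyl from propylcarbonyl on the saturated chain carbon bound to the carbonyl carbon (a 1.5-fold lower number from compound 3 to compound 4 (0.19 log units; within the scatter)). The large gap to the cyclopropyl-bearing arm of compound 1 persists with the longer acyl group (a 29-fold higher number from compound 1 to compound 4 (1.47 log units; beyond the scatter)), so this acyl exchange does not close the distance seen with the acetyl compound. No measurement at hand speaks to the cause of either step.

Still open, going by these compounds, is how a propanoyl amide or a longer chain such as pentanoyl would read on the propyl arm, and whether the same ethyl-for-hydrogen exchange gives a comparable result on the cyclopropyl arm. The share of the gap that belongs to the cyclopropane alone, with the acyl group held constant, also remains unresolved.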